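The source may hold more compounds than are shown below. What is called first, only, known or untested is meant among the compounds shown, and "the series" means these compounds.

Measured in an ADME assay on MT4 cells (Homo sapiens) for cytotoxicity, read by MTT assay; on this read-out lower numbers stand for higher toxicity in this test and higher numbers for lower toxicity in this test:
- Compound 1 `Cc1ccc(C(=O)N(C(=S)OCCN2C(=O)c3ccccc3C2=O)c2ccc(Cl)cc2)cc1`: > 100000 nM (a limit)
- Compound 2 `O=C1c2ccccc2C(=O)N1CCOC(=S)N(C(=O)c1ccc([N+](=O)[O-])cc1)c1ccc(Cl)cc1`: > 100000 nM (a limit)
- Compound 3 `O=C1c2ccccc2C(=O)N1CCOC(=S)N(C(=O)c1cccc(F)c1F)c1ccc(Cl)cc1`: 58000 nM

Compound 3 alone gives an actual number, so it cannot be ranked exactly against the others. The other two results are limits: the limit of > 100000 nM in this assay, at which 2 of the 3 values shown sit.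

Compound 4 `O=C1c2ccccc2C(=O)N1CCOC(=S)N(C(=O)c1cc(F)ccc1F)c1ccc(Cl)cc1` has the same atoms as compound 3, joined differently, with 2,5-difluorophenyl in place of 2,3-difluorophenyl on a carbonyl carbon.

Two measured steps change the group at this carbonyl carbon: an at least 1.7-fold lower number from compound 1 to compound 3 (0.23 log units; that floor lies within the scatter) and an at least 1.7-fold lower number from compound 2 to compound 3 (0.23 log units; that floor lies within the scatter). Both give only a floor, and neither swaps one difluorophenyl for another. No change beyond the scatter is therefore expected in this assay.

The expected step is a 1.0-fold higher number from compound 3 to compound 4 (0.01 log units; within the scatter).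

For compound 4 the estimated value is 60000 nM, with an expected range from 25000 nM to 100000 nM.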

Compound 4, half-maximal cytotoxic concentration: 54000 nM
Compound 4: the middle estimate sits 1.1-fold (0.05 log units) above what was measured; the measured number falls inside the stated range.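

In this assay, putting 2,5-difluorophenyl in place of 2,3-difluorophenyl on the carbonyl carbon gives a 1.1-fold lower number from compound 3 to compound 4 (0.03 log units; within the scatter), so this first swap of one difluorophenyl for another shows no real change. Against the other two groups, the steps are an at least 1.8-fold lower number from compound 2 to compound 4 (0.26 log units; that floor lies within the scatter) and an at least 1.8-fold lower number from compound 1 to compound 4 (0.26 log units; that floor lies within the scatter). These steps are only floors, since compound 1 and compound 2 each give a limit rather than a number: the limit of > 100000 nM in this assay, at which 2 of the 4 values shown sit.

As far as these compounds go, how far compound 1 and compound 2 truly lie from compound 4 stays open. So does whether an amine or a carboxylic acid on this aromatic ring, or a pyridine ring in its place, would move the number beyond the scatter.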